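The source may hold more compounds than are shown below. What is called first, only, known or untested is meant among the compounds shown, and "the series" means these compounds.

Compound 3 `COc1ccc(/C=N/NC(=O)c2ccc(-c3nnc(-c4ccccc4OC)o3)cc2)cc1O` gives 260000 nM in an ADME assay on THP-1 cells (Homo sapiens) for cytotoxicity (a lower number here means a stronger inhibitor, a higher number a weaker inhibitor), the second highest of the three numbers: near compound 1 `COc1ccccc1-c1nnc(-c2ccc(C(=O)N/N=C/c3ccc(F)cc3)cc2)o1`, which gives 427000 nM, and far from compound 2 `COc1ccccc1-c1nnc(-c2ccc(C(=O)N/N=C/c3c(O)cc(O)cc3O)cc2)o1`, which gives 12400 nM. Compound 4 `COc1ccc(/C=N/NC(=O)c2ccc(-c3nnc(-c4ccccc4OC)o3)cc2)c(O)c1` differs from compound 3 by 2-hydroxy-4-methoxyphenyl in place of 3-hydroxy-4-methoxyphenyl on a carbon with a double bond to nitrogen. Going by the values given here, the measured steps of a 34-fold lower number from compound 1 to compound 2 (1.54 log units; beyond the scatter), a 21-fold higher number from compound 2 to compound 3 (1.32 log units; beyond the scatter) and a 1.6-fold lower number from compound 1 to compound 3 (0.22 log units; within the scatter) all change the number or kind of substituents on that ring; none rearranges the same hydroxyl and methoxy groups, so no step bears directly on this change. Only compound 2, whose ring also carries a hydroxyl at the 2-position, hints at a lower number with 12400 nM. Compound 4 is therefore expected at 150000 nM, between 30000 nM and 450000 nM, a step of a 1.7-fold lower number from compound 3 to compound 4 (0.24 log units; within the scatter) that may well stay within the scatter.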

Compound 4, half-maximal inhibitory concentration: 308000 nM
Compound 4: the middle estimate sits 2.1-fold (0.31 log units) below what was measured; the range from low to high includes it.
By their numbers in this assay, from the lowest: compound 2; then compounds 3, 4 and 1 (each within the scatter of the next).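

In this assay, 2-hydroxy-4-methoxyphenyl in place of 3-hydroxy-4-methoxyphenyl on the carbon with a double bond to nitrogen rearranges the same atoms, and the two compounds cannot be told apart (a 1.2-fold higher number from compound 3 to compound 4 (0.07 log units; within the scatter)). Compound 4 does not share the low number of the 2,4,6-trihydroxyphenyl compound (a 25-fold higher number from compound 2 to compound 4 (1.40 log units; beyond the scatter)) and cannot be told apart from the 4-fluorophenyl compound (a 1.4-fold lower number from compound 1 to compound 4 (0.14 log units; within the scatter)). No supporting evidence bears on why these groups give these numbers. Still open, from the compounds shown here alone, is whether compound 2 needs the full 2,4,6-trihydroxyphenyl pattern for its low number, and what an amine or a carboxylic acid on this ring would give.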